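A few compounds are considered here, and "the series" means these few. Any claim that something is new, unique, unknown or untested is made for them only; others in the source may bear on it.

In a functional assay on QGY7701 cells (Homo sapiens) for cytotoxicity, read by MTT assay, with a stated time of 48 h (a lower number here means a stronger inhibitor, a higher number a weaker inhibitor), compound 1 `Cc1cccc(Cn2cc(COc3ccc4c(=O)ccoc4c3)nn2)c1` gives 22400 nM. Compound 3 `O=c1ccoc2cc(OCc3cn(Cc4ccccc4Cl)nn3)ccc12` gives 19700 nM, and the two differ by a 1.1-fold lower number from compound 1 to compound 3 (0.06 log units; within the scatter). Compound 2 `Cc1ccccc1Cn1cc(COc2ccc3c(=O)ccoc3c2)nn1` reaches only > 100000 nM, which is a limit of the assay rather than a measured number; it sits at the limit of > 100000 nM in this assay, at which 1 of the 3 values shown sits. Relative to compound 2, the steps of an at least 4.4-fold higher number from compound 1 to compound 2 (0.64 log units; beyond the scatter) and an at least 5.0-fold lower number from compound 2 to compound 3 (0.70 log units; beyond the scatter) both show that moving away from the 2-methylphenyl on a saturated chain carbon bound to an aromatic nitrogen gives a clearly lower number. Compound 4 `O=c1ccoc2cc(OCc3cn(Cc4ccc([N+](=O)[O-])cc4)nn3)ccc12` carries the change (4-nitrophenyl in place of 2-methylphenyl on a saturated chain carbon bound to an aromatic nitrogen). Given that both measured steps away from compound 2, an at least 4.4-fold higher number from compound 1 to compound 2 (0.64 log units; beyond the scatter) and an at least 5.0-fold lower number from compound 2 to compound 3 (0.70 log units; beyond the scatter), were beyond the scatter, a lower number is expected for compound 4, a step of roughly an at least 4.0-fold lower number from compound 2 to compound 4 (0.60 log units; beyond the scatter). Compound 4 is therefore estimated at 25000 nM, likely between 8000 nM and 100000 nM.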

Compound 4, half-maximal inhibitory concentration: > 100000 nM
Compound 4: no number, only a limit; the forecaster's own chance of this, stated with the estimate: 25%; middle value at least 4.0-fold (0.60 log units) from the limit.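

Leaving the 2-methylphenyl does not by itself give a lower number: compound 4, with its 4-nitrophenyl, also ends at a limit of the assay rather than a measured number. The change reads clearly against the measured compounds, with an at least 5.0-fold higher number from compound 3 to compound 4 (0.70 log units; beyond the scatter) and an at least 4.4-fold higher number from compound 1 to compound 4 (0.64 log units; beyond the scatter), whereas the step between compound 2 and compound 4 cannot be read. Compound 2 and compound 4 now share one ceiling: the limit of > 100000 nM in this assay, at which 2 of the 4 values shown sit.

The compounds shown do not separate the nitro group itself from its place on the ring. From the compounds shown here alone, how an amine in place of the nitro group would read out also stays open.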